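A few compounds are considered here, and "the series" means these few. Any claim that something is new, unique, unknown or untested is made for them only; others in the source may bear on it.

Measured so far in a functional assay on MCF7 cells (Homo sapiens) for cytotoxicity, read by CCK-8 assay, with a stated time of 24 h; on this read-out lower numbers stand for stronger inhibition and higher numbers for weaker inhibition:
Compound 1, `C/C(=C\c1ccc(-c2ccc(C)cc2)o1)C(N)=O`, gives only a limit of the assay, > 50000 nM.
Compound 2, `C/C(=C\c1ccc(-c2ccc(F)cc2)o1)C(N)=O`, gives 970 nM.
Compound 3, `C/C(=C\c1nc(-c2ccc(C)cc2)cs1)C(N)=O`, gives only a limit of the assay, > 50000 nM.

Going by the values given here, the one counted step in this assay is an at least 51-fold lower number from compound 1 to compound 2 (1.71 log units; beyond the scatter), brought by fluoro in place of methyl on an aromatic carbon. The difference between the core of compound 1 and the core of compound 3 is not broken down here. Compound 4, `C/C(=C\c1nc(-c2ccc(F)cc2)cs1)C(N)=O`, is still to be measured in this assay; it differs from compound 3 by fluoro in place of methyl on an aromatic carbon, the same change as from compound 1 to compound 2. On these data alone, compound 3 sits at the limit of > 50000 nM in this assay, at which 2 of the 3 values shown sit, so the size of any step down from it is open. The step from compound 3 to compound 4 is expected to be an at least 16-fold lower number from compound 3 to compound 4 (1.22 log units; beyond the scatter), resting on an at least 51-fold lower number from compound 1 to compound 2 (1.71 log units; beyond the scatter), although the two cores differ. Compound 4 is therefore expected at 3000 nM, somewhere between 500 nM and 50000 nM.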

Compound 4, half-maximal inhibitory concentration: 3300 nM
Compound 4: middle estimate off by 1.1-fold (0.04 log units), on the low side; low and high end bracket the measured number.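

In this assay, fluoro in place of methyl on an aromatic carbon gives an at least 15-fold lower number from compound 3 to compound 4 (1.18 log units; beyond the scatter), so on this second core the change again moves the number down, beyond the scatter. The size of the change is not shown to carry over, as both steps are bounded by a limit rather than fixed by two measured values: the same change on two cores in this assay, an at least 51-fold lower number (1.71 log units; beyond the scatter) from compound 1 to compound 2 and an at least 15-fold lower number (1.18 log units; beyond the scatter) from compound 3 to compound 4; the limit leaves it open whether they differ

Two cores, each with a single pair, show nothing about cores beyond these. On these data alone, how chloro or methoxy at the same place would read remains open, leaving it unsettled whether the drop is specific to fluoro. Also open, as far as these compounds go, is what a carboxylic acid in place of the amide would do on either core.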